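The compounds below may be only part of what the source reports. "The series", "measured", "known", "first", "only" and "open" are said of these compounds alone.

Working notes on the sulfonamide series.

Compound 1 `O=C1NCCN1c1ccc(S(=O)(=O)Nc2ccc(I)cc2)cc1` is the reference point. Among the compounds with values here, in a functional assay on M21 cells (Homo sapiens) for antiproliferative activity, read by sulforhodamine B assay, with a stated time of 48 h (on this read-out higher numbers stand for weaker inhibition and lower numbers for stronger inhibition), compound 1 gives 260 nM, the lowest of the two numbers so far. Compound 2 `CCCCOc1ccc(NS(=O)(=O)c2ccc(N3CCNC3=O)cc2)cc1` carries butoxy in place of iodo on an aromatic carbon, and in this assay compound 2 gives 580 nM; the step is a 2.2-fold higher number from compound 1 to compound 2 (0.35 log units; beyond the scatter). Compound 3 `CC(C)Cc1ccc(NS(=O)(=O)c2ccc(N3CCNC3=O)cc2)cc1` carries isobutyl in place of iodo on an aromatic carbon. In this assay compound 3 reaches only a limit of the assay, > 1000 nM. Against compound 1 that step is an at least 3.8-fold higher number from compound 1 to compound 3 (0.58 log units; beyond the scatter), and from compound 2 it is an at least 1.7-fold higher number from compound 2 to compound 3 (0.23 log units; that floor lies within the scatter). Both replacements of the iodo group so far have moved the number upward.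

Compound 4 `Cc1ccccc1NS(=O)(=O)c1ccc(N2CCNC2=O)cc1` is not yet measured. The change from compound 1 is 2-methylphenyl in place of 4-iodophenyl on a sulfonamide nitrogen. The two measured steps that bear on it, both replacing iodo, were modest or at least modest in the weakening direction, so a step of similar direction and size is expected for compound 4 in this assay: the expected step is a 3.1-fold higher number from compound 1 to compound 4 (0.49 log units; beyond the scatter). Compound 4 is therefore estimated at 800 nM, with a range from 300 nM to 2500 nM, and the measurement will tell.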

Compound 4, half-maximal inhibitory concentration: 150 nM
The estimate for compound 4 lay 5.3-fold (0.73 log units) above the measured number; the whole stated range lies above it.
By their numbers in this assay, from the lowest: compounds 4 and 1 (each within the scatter of the next); then compound 2. At a limit, above all of these: compound 3.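

Exchanging the whole 4-iodophenyl on the sulfonamide nitrogen for 2-methylphenyl gives a 1.7-fold lower number from compound 1 to compound 4 (0.24 log units; within the scatter) in this assay. Unlike the butoxy and isobutyl replacements of iodo, this change leaves the number of the parent within the scatter, so within these compounds an iodine atom on the aromatic ring is not required to keep the number at the level of compound 1, and a small alkyl group named 2-methyl on that ring is compatible with it. The results shown include no measurement that bears on why this group holds the number at that level.

The compounds shown leave open how 4-methylphenyl, 2-iodophenyl or unsubstituted phenyl would compare on the sulfonamide nitrogen, so the effect of exchanging iodo for methyl cannot be separated from the effect of where the group sits on the ring. Also open, as far as these compounds go, is whether an amine or a carboxylic acid on that ring would hold the number at this level in this assay.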